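This account rests on a few compounds, and the source may have more. Where it says the series, first, only, none or still open, it means among the compounds named here.

Compound 1 `Cc1ccc(Cn2c(=O)[nH]c3c(N)nc(-c4ncco4)cc32)cn1` gives < 7 mL.min-1.g-1 in an in vitro ADME assay on microsomes from liver (Homo sapiens) for metabolic stability; on this read-out lower numbers stand for slow clearance and higher numbers for fast clearance; this is a limit of the assay.
Compound 2 `Cc1ccc(Cn2c(=O)[nH]c3c(N)nc(C(F)(F)F)cc32)cn1` gives < 7 mL.min-1.g-1 in this assay; this too is a limit.
Compound 3 `Cc1cccc(Cn2c(=O)[nH]c3c(N)nc(C(F)(F)F)cc32)n1` gives < 8 mL.min-1.g-1 in this assay; again a limit.

Compound 3 therefore stands at the limit of < 8 mL.min-1.g-1 in this assay, at which 1 of the 3 values shown sits, while the other two sit at the limit of < 7 mL.min-1.g-1 in this assay, at which 2 of the 3 values shown sit. The steps a step that the two limits leave unreadable from compound 1 to compound 2 and a step that the two limits leave unreadable from compound 2 to compound 3 cannot be read, since every value is a limit. Compound 4 `Cc1nc(Cn2c(=O)[nH]c3c(N)nc(C(F)(F)F)cc32)cs1` differs from compound 3 by 2-methyl-1,3-thiazol-4-yl in place of 6-methylpyridin-2-yl on a saturated chain carbon bound to an aromatic nitrogen. Among the measured compounds shown here, no measured step gives a readable size for such a change, and all three compounds share the same shared core at a limit, so compound 4 is expected to remain there as well. The step that the limit leaves unreadable from compound 3 to compound 4 is expected to be none beyond the scatter. Compound 4 is estimated at 4 mL.min-1.g-1, within 1 mL.min-1.g-1 to 10 mL.min-1.g-1.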

Compound 4, intrinsic clearance in microsomes: < 7 mL.min-1.g-1
Compound 4: no number, only a limit (the forecaster's own chance of this, stated with the estimate: 80%); the middle value lies beyond the limit too.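

In this assay compound 4 gives < 7 mL.min-1.g-1, again a limit, so its steps from compound 2 and compound 3 cannot be read. The compounds shown leave open whether changing the group on the saturated chain carbon alters clearance at all in this assay.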